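Ethoxycarbonyl to carboxy: the step to compound 4

A few compounds are considered here, and "the series" means these few. Any claim that something is new, unique, unknown or untested is made for them only; others in the source may bear on it.

Measured in a functional assay on BAEC cells (Bos taurus) for antiproliferative activity, read by cell counting, with a stated time of 4 days; a lower number here means a stronger inhibitor, a higher number a weaker inhibitor:
Compound 1 `CCOC(=O)CN(Cc1ccc(F)cc1)c1ccc2c(c1)OC(C)(COc1ccc(C#N)cc1)CN2C` gives 50000 nM
Compound 2 `CCOC(=O)CN(Cc1cc(F)cc(F)c1)c1ccc2c(c1)OC(C)(COc1ccc(C#N)cc1)CN2C` gives 25000 nM
Compound 3 `CCOC(=O)C(=O)N(Cc1ccccc1)c1ccc2c(c1)OC(C)(CO)CN2C` gives > 100000 nM as a limit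

Compound 3 stands only at a limit (> 100000 nM) and has no number in this assay here. Compound 4 `CN1CC(C)(CO)Oc2cc(N(Cc3ccccc3)C(=O)C(=O)O)ccc21` differs from compound 3 by one change (hydrogen in place of ethyl on an oxygen next to a carbonyl group): ethoxycarbonyl becomes carboxy. Among the measured compounds shown here, the only measured step (a 2.0-fold lower number from compound 1 to compound 2 (0.30 log units; within the scatter)) lies within the scatter and sits elsewhere in the structure, so it gives no guide to this change. No direction can be fixed, and no step beyond the scatter is expected in this assay on these data. The expected step, an estimate only, is a number no higher from compound 3 to compound 4 (the limit leaves the size open) in size. Compound 4 is estimated at 100000 nM (expected range 30000 nM to 300000 nM) in this assay when it is measured.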

Compound 4, half-maximal inhibitory concentration: > 100000 nM
Compound 4 was reported as a limit; the forecaster's own chance of this, stated with the estimate: 70%; the middle value lies on the limit itself.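

Compound 3 and compound 4 both stand only at a limit in this assay, so no step between them can be read: the limit of > 100000 nM in this assay, at which 2 of the 4 values shown sit.

The compounds shown leave open whether ethoxycarbonyl and carboxy differ at all in this assay.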